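The compounds below may be only part of what the source reports. "The series", "measured", "known", "first", "only" and "open" are said of these compounds alone.

- Compound 1 `COc1ccc(/C=C/c2cc(OC)cc(OC)c2/C=C/C(=O)c2ccc(Cl)c(Cl)c2)cc1`: 10.8 ug/mL
- Compound 2 `COc1ccc(/C=C/c2cc(OC)cc(OC)c2/C=C/C(=O)c2ccc(Cl)cc2)cc1`: 13.6 ug/mL
- Compound 3 `COc1ccc(/C=C/c2cc(OC)cc(OC)c2/C=C/C(=O)c2ccc(OC)cc2)cc1`: 4.9 ug/mL

These values come from a functional assay on HepG2 cells (Homo sapiens) for antiproliferative activity, read by MTT assay, with a stated time of 48 h; on this read-out lower numbers stand for stronger inhibition and higher numbers for weaker inhibition. Of the three, compound 3 has the lowest number. The steps reaching it are modest but beyond the scatter: a 2.2-fold lower number from compound 1 to compound 3 (0.34 log units; beyond the scatter) and a 2.8-fold lower number from compound 2 to compound 3 (0.44 log units; beyond the scatter). Compound 4 `COc1ccc(/C=C/c2cc(OC)cc(OC)c2/C=C/C(=O)c2ccc(C)c(C)c2)cc1` remains unmeasured and carries 3,4-dimethylphenyl in place of 4-methoxyphenyl on a carbonyl carbon, with 3,4-dimethylphenyl in place of 4-methoxyphenyl on a carbonyl carbon. Among the compounds with values here, no measured step introduces this group. Within the data shown here, the closest precedent is the exchange between 3,4-dichlorophenyl and 4-methoxyphenyl, a 2.2-fold lower number from compound 1 to compound 3 (0.34 log units; beyond the scatter), so a small rise in the number is expected in this assay, probably within the scatter. The expected change is a 1.6-fold higher number from compound 3 to compound 4 (0.21 log units; within the scatter). For compound 4 the estimate is 8 ug/mL, with an expected range from 4 ug/mL to 16 ug/mL.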

Compound 4, half-maximal inhibitory concentration: 0.2 ug/mL
Compound 4: middle estimate off by 40-fold (1.60 log units), on the high side; measured number outside the range, below it.
By their numbers in this assay, from the lowest: compound 4; then compound 3; then compounds 1 and 2 (each within the scatter of the next).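

Changing the group on the carbonyl carbon to 3,4-dimethylphenyl gives a 25-fold lower number from compound 3 to compound 4 (1.39 log units; beyond the scatter) in this assay, and the steps from the chlorinated compounds are a 68-fold lower number from compound 2 to compound 4 (1.83 log units; beyond the scatter) and a 54-fold lower number from compound 1 to compound 4 (1.73 log units; beyond the scatter). The earlier exchanges among 3,4-dichlorophenyl, 4-chlorophenyl and 4-methoxyphenyl had shown only modest steps at most, so this position can shift the number far more than they suggested. No available evidence bears on the size of this shift. The compounds shown leave open whether both methyl groups are needed, which 4-methylphenyl on the same carbonyl carbon would test, and how 3,4-diethylphenyl would compare.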